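Hexyl to 2-Methoxyphenyl on the Ring Nitrogen: a Forecast

The source may hold more compounds than are shown below. What is called first, only, known or untested is meant among the compounds shown, and "the series" means these compounds.

Measured so far:
Compound 1 `CCCCCCNc1nc(SCc2ccc(C(F)(F)F)cc2)nc2ccccc12` in a functional assay on MDA-MB-231 cells (Homo sapiens) for cytotoxicity, read by MTT assay, with a stated time of 72 h (on this read-out higher numbers stand for weaker inhibition and lower numbers for stronger inhibition), gives 20200 nM
Compound 2 `FC(F)(F)c1ccc(CSc2nc(Nc3ccccc3Cl)c3ccccc3n2)cc1` in this assay gives > 50000 nM; this is a limit, not a number

Within the data shown here, compound 1 holds the only actual number reported; the other result is a limit. Compound 2 sits at the limit of > 50000 nM in this assay, at which 1 of the 2 values shown sits. Among the measured compounds shown here, the single measured step, an at least 2.4-fold higher number from compound 1 to compound 2 (0.39 log units; beyond the scatter), swaps the hexyl chain for a 2-chlorophenyl group. Compound 3 `COc1ccccc1Nc1nc(SCc2ccc(C(F)(F)F)cc2)nc2ccccc12` makes a closely related change on compound 1: 2-methoxyphenyl in place of hexyl on a nitrogen on an aromatic ring. Because the aryl-for-alkyl exchange in an at least 2.4-fold higher number from compound 1 to compound 2 (0.39 log units; beyond the scatter) weakened inhibition, a weakening of similar size is expected here, with a fair chance that only a limit is returned. Compound 3 is therefore estimated at 45000 nM (range 20000 nM to 100000 nM). That estimate implies an expected step of a 2.2-fold higher number from compound 1 to compound 3 (0.35 log units; beyond the scatter).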

Compound 3, half-maximal inhibitory concentration: > 50000 nM
Compound 3: no number, only a limit; the forecaster's own chance of this, stated with the estimate: 55%; middle value at least 1.1-fold (0.04 log units) from the limit.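

Putting 2-methoxyphenyl in place of hexyl on a nitrogen on an aromatic ring gives an at least 2.4-fold higher number from compound 1 to compound 3 (0.39 log units; beyond the scatter). Inhibition therefore also weakens with a methoxy-bearing aromatic ring, not only with the chloro-bearing one, although the result for compound 3 is a limit, not a number. Compound 2 and compound 3 now share that limit: the limit of > 50000 nM in this assay, at which 2 of the 3 values shown sit.

The step between compound 2 and compound 3 cannot be read, so methoxy and chloro remain unranked. As far as these compounds go, whether a shorter chain such as butyl or a saturated ring such as cyclohexyl on this nitrogen would match compound 1 stays open.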